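This account rests on a few compounds, and the source may have more. Where it says the series, first, only, none or still open, it means among the compounds named here.

Compound 3 `COc1cccc(CNCCCNc2ccnc3cc(CCc4ccccc4)ccc23)c1O` gives 23 10^-6 cm/s in an ADME assay for permeability, using PAMPA, with a stated time of 30 min, at pH 7.4 (a lower number here means that the compound crosses the layer more slowly, a higher number that the compound crosses the layer faster), level with compound 1 `COc1cccc(CNCCCNc2ccnc3cc(Cc4cc(C)cc(C)c4)ccc23)c1O`, which gives 23 10^-6 cm/s in this assay; the two together sit lowest of the three numbers, while compound 2 `COc1ccc(F)cc1CNCCCNc1ccnc2cc(-c3cccc4ccccc34)ccc12` gives 237 10^-6 cm/s, the highest. From compound 3 to compound 4 `COc1cccc(CNCCCNc2ccnc3cc(-c4cccc5ccccc45)ccc23)c1O` the change is naphthalen-1-yl in place of phenethyl on an aromatic carbon. Going by the values given here, only one measured step exists, no change at the digits printed from compound 1 to compound 3 (within the scatter), and it concerns a different change, so no direct precedent is available. Compound 2 carries the same naphthalen-1-yl group and is far higher than compound 3, but it also differs elsewhere. A moderate rise is therefore expected, with a 3.0-fold higher number from compound 3 to compound 4 (0.48 log units; beyond the scatter). Compound 4 is estimated at 70 10^-6 cm/s, within a range from 25 10^-6 cm/s to 200 10^-6 cm/s.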

Compound 4, apparent permeability: 237 10^-6 cm/s
For compound 4 the middle estimate is 3.4-fold (0.53 log units) below the measured one; the whole stated range lies below it.
By their numbers in this assay, from the lowest: compounds 1 and 3 (each within the scatter of the next); then compounds 2 and 4 (each within the scatter of the next).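

In this assay, naphthalen-1-yl on this aromatic carbon gives a 10-fold higher number from compound 3 to compound 4 (1.01 log units; beyond the scatter) in place of phenethyl and a 10-fold higher number from compound 1 to compound 4 (1.01 log units; beyond the scatter) in place of 3,5-dimethylbenzyl, so the group here can move the number strongly, which the earlier step between two chain-linked groups did not show. Placing 2-hydroxy-3-methoxyphenyl for 5-fluoro-2-methoxyphenyl gives no change at the digits printed from compound 2 to compound 4 (within the scatter) while naphthalen-1-yl stays. Nothing available explains the rise. On these data alone, whether phenyl or naphthalen-2-yl on this aromatic carbon would give the higher or the lower level remains open.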